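This account rests on a few compounds, and the source may have more. Where it says the series, first, only, none or still open, it means among the compounds named here.

In an assay for binding affinity to Sigma non-opioid intracellular receptor 1 (Rattus norvegicus) (on this read-out lower numbers stand for stronger inhibition and higher numbers for weaker inhibition), compound 1 `Brc1ccc(OCC2CCN(CC3CC3)CC2)cc1` gives 0.6 nM. Compound 2 `N#Cc1ccccc1CN1CCC(COc2ccc(I)cc2)CC1` gives 10.5 nM in this assay, the higher of the two numbers, and its separation from compound 1 lies beyond the usual scatter. Compound 3 `N#Cc1cccc(CN2CCC(COc3ccc(I)cc3)CC2)c1` differs from compound 2 in a single respect: 3-cyanophenyl in place of 2-cyanophenyl on a saturated chain carbon bound to an amine nitrogen in a ring. Going by the values given here, no measured pair shows what such a move of the nitrile does, so the outcome rests on expectation alone. The step from compound 2 to compound 3 in this assay is expected to be modest, a 1.8-fold lower number from compound 2 to compound 3 (0.24 log units; within the scatter), tending toward a somewhat lower number. Compound 3 is accordingly estimated at 6 nM, within 1.5 nM to 25 nM.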

Compound 3, inhibition constant in the Sigma non-opioid intracellular receptor 1 assay: 2.9 nM
Compound 3: middle estimate off by 2.1-fold (0.32 log units), on the high side; the range from low to high includes it.
By their numbers in the Sigma non-opioid intracellular receptor 1 assay, from the lowest: compound 1; then compound 3; then compound 2.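

In the Sigma non-opioid intracellular receptor 1 assay, compound 2 gives 10.5 nM and compound 3 gives 2.9 nM: the move of the nitrile gives a 3.6-fold lower number from compound 2 to compound 3 (0.56 log units; beyond the scatter), so on a saturated chain carbon bound to an amine nitrogen in a ring, 3-cyanophenyl and 2-cyanophenyl are not interchangeable, although they hold the same atoms. In a physicochemical assay for lipophilicity (on this read-out lower numbers stand for lower lipophilicity and higher numbers for higher lipophilicity), compound 2 gives 4.32 and compound 3 gives 4.19: the same change gives a number 0.13 log units lower from compound 2 to compound 3 (within the scatter), which lies within the scatter. Nothing at hand bears on the reason for the step in binding. Left open is how a carboxylic acid or an amide in place of the nitrile would read in the Sigma non-opioid intracellular receptor 1 assay, and whether the step would hold on the core of compound 1.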